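The source may report more compounds than this note shows. Statements on the series, on what has been measured and on what is new or still open speak of the compounds shown alone.

Measured in a toxicity assay on Huh-7 cells (Homo sapiens) for cytotoxicity, read by CCK-8 assay, with a stated time of 24 h; on this read-out lower numbers stand for higher toxicity in this test and higher numbers for lower toxicity in this test:
- compound 1 `O=c1cc(-c2ccc(Nc3ccc(F)cc3)cc2)oc2cc(O)c(O)c(O)c12`: > 100000 nM (a limit)
- compound 2 `CN1CCN(c2ccc(-c3cc(=O)c4c(O)c(O)c(O)cc4o3)cc2)CC1`: > 100000 nM (a limit)
- compound 3 `O=c1cc(-c2ccc(N3CCN(c4cccc(Cl)c4)CC3)cc2)oc2cc(O)c(O)c(O)c12`: > 100000 nM (a limit)

Compound 2 has no number on this read-out, only the limit > 100000 nM. All the measurements so far rest on (the limit of > 100000 nM in this assay, at which 3 of the 3 values shown sit).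

Compound 4 `O=c1cc(-c2ccc(Nc3ccc(Cl)cc3)cc2)oc2cc(O)c(O)c(O)c12` has not yet been measured. It carries the change ((4-chlorophenyl)amino in place of 4-methylpiperazin-1-yl on an aromatic carbon), with (4-chlorophenyl)amino in place of 4-methylpiperazin-1-yl on an aromatic carbon.

The closest measured change is a step that the two limits leave unreadable from compound 1 to compound 2, where 4-methylpiperazin-1-yl replaces (4-fluorophenyl)amino on an aromatic carbon. The other is a step that the two limits leave unreadable from compound 2 to compound 3, where 3-chlorophenyl replaces methyl on an amine nitrogen in a ring. Neither step has a readable size, so neither gives a direction.

The expectation rests instead on compound 1, which holds (4-fluorophenyl)amino and gives only the limit > 100000 nM. No step beyond the scatter is therefore expected in this assay, and the expected step is a number no higher from compound 2 to compound 4 (the limit leaves the size open). The most likely report is another limit, although a number close to it remains possible. For compound 4 the estimate is 100000 nM, with an expected range from 50000 nM to 200000 nM.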

Compound 4, half-maximal cytotoxic concentration: > 100000 nM
Compound 4 gave a limit, no number; the forecaster's own chance of this, stated with the estimate: 80%; the middle value sits exactly at the limit.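

In this assay compound 4 gives > 100000 nM, which is a limit and not a number. Its steps from compound 1 and from compound 2 cannot be read. The compounds shown leave open whether any of them differ at all in this assay, since all the values rest on one limit: the limit of > 100000 nM in this assay, at which 4 of the 4 values shown sit.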